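Swapping 4-methylphenyl for 3-hydroxyphenyl on a shared core

A few compounds are considered here, and "the series" means these few. Any claim that something is new, unique, unknown or untested is made for them only; others in the source may bear on it.

Values measured in a functional assay on HCT-116 cells (Homo sapiens) for inhibition, read by MTT assay, with a stated time of 48 h (on this read-out higher numbers stand for weaker inhibition and lower numbers for stronger inhibition), are these:
Compound 1 `COc1cc(-c2cc(-c3ccc(Br)cc3)nc(-c3ccccc3)n2)cc(OC)c1OC` gives 4320 nM
Compound 2 `COc1cc(-c2cc(-c3cccc([N+](=O)[O-])c3)nc(-c3ccccc3)n2)cc(OC)c1OC` gives > 25000 nM (a limit of the assay, not a number)
Compound 3 `COc1cc(-c2cc(-c3ccc(C)cc3)nc(-c3ccccc3)n2)cc(OC)c1OC` gives 15700 nM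

Of the two actual numbers, compound 3 holds the higher at 15700 nM and compound 1 is its nearest neighbour, as a 3.6-fold higher number from compound 1 to compound 3 (0.56 log units; beyond the scatter) shows. Within the data shown here, compound 4 `COc1cc(-c2cc(-c3cccc(O)c3)nc(-c3ccccc3)n2)cc(OC)c1OC` carries 3-hydroxyphenyl in place of 4-methylphenyl on an aromatic carbon and no measured compound has this group. The closest comparison is compound 2 with its 3-nitrophenyl, and an at least 1.5-fold lower number from compound 2 to compound 3 (0.20 log units; that floor lies within the scatter) does not separate it from compound 3. Moving away from 4-bromophenyl raised the number both times, in an at least 5.7-fold higher number from compound 1 to compound 2 (0.76 log units; beyond the scatter) and in a 3.6-fold higher number from compound 1 to compound 3 (0.56 log units; beyond the scatter), so among these three only compound 1 stands apart. Compound 4 also lacks 4-bromophenyl and is therefore expected to stay with compound 2 and compound 3 rather than approach compound 1. The estimated change, a 1.1-fold lower number from compound 3 to compound 4 (0.05 log units; within the scatter), is expected to be no step beyond the scatter. For compound 4 the expected value in this assay is 14000 nM, with an estimated range from 6000 nM to 25000 nM as its ends.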

Compound 4, half-maximal inhibitory concentration: 20400 nM
Estimate against measurement, compound 4: 1.5-fold (0.16 log units) below, within the range that was stated.
By their numbers in this assay, from the lowest: compound 1; then compounds 3 and 4 (each within the scatter of the next). At a limit, above all of these: compound 2.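

With 3-hydroxyphenyl in place of 4-methylphenyl, a ring with a hydrogen-bond donor and acceptor takes a place that held neither, yet in this assay the result stays within the scatter, as a 1.3-fold higher number from compound 3 to compound 4 (0.11 log units; within the scatter) shows. The same group also gives a 4.7-fold higher number from compound 1 to compound 4 (0.67 log units; beyond the scatter), so all three groups shown in place of 4-bromophenyl now give higher numbers than compound 1, and none of the compounds goes against this. The remaining step, an at least 1.2-fold lower number from compound 2 to compound 4 (0.08 log units; that floor lies within the scatter), starts from a limit of the assay and its floor lies within the scatter, so it sets no order between the two compounds: the limit of > 25000 nM in this assay, at which 1 of the 4 values shown sits.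

Compound 3 and compound 4 differ in both the substituent and its place on the phenyl ring, so the compounds shown do not separate these two changes, and 3-methylphenyl or 4-hydroxyphenyl would be needed to do so. They also leave open whether the low number of compound 1 is particular to bromo or extends to a 4-chlorophenyl or 4-iodophenyl group, and how an amine or a carboxylic acid would fare at this position.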